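Urea to amide at the anilide carbonyl of compound 3

This account rests on a few compounds, and the source may have more. Where it says the series, first, only, none or still open, it means among the compounds named here.

Three members of the series have numbers in a functional assay on OVCAR-4 cells (Homo sapiens) for inhibition, read by sulforhodamine B assay, with a stated time of 48 h, tested at 1 uM; on this read-out lower numbers stand for a stronger effect and higher numbers for a weaker effect at the one concentration tested. Compound 1 `COc1cc(Cl)cc(-c2nn(-c3cccc(NC(=O)Nc4ccc(Cl)c(C(F)(F)F)c4)c3)cc2-c2ccncc2)c1` gives 62% in this assay; compound 2 `COc1cc(Cl)cc(-c2nn(-c3cccc(NC(=O)Nc4ccc(Cl)c(Cl)c4)c3)cc2-c2ccncc2)c1` gives 83%; compound 3 `COc1cc(Cl)cc(-c2nn(-c3cccc(NC(=O)Nc4cccc(C(F)(F)F)c4)c3)cc2-c2ccncc2)c1` gives 71%. The measured steps all change the distal aryl of the urea: a number 21 percentage points higher from compound 1 to compound 2 (beyond the scatter), a number 9 percentage points higher from compound 1 to compound 3 (within the scatter), and a number 12 percentage points lower from compound 2 to compound 3 (beyond the scatter). Compound 3 thus sits apart from compound 2 by a modest amount, while its gap to compound 1 falls within the scatter, so compound 1 and compound 3 are not separated on this read-out.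

Compound 4 `COc1cc(Cl)cc(-c2nn(-c3cccc(NC(=O)c4cccc(C(F)(F)F)c4)c3)cc2-c2ccncc2)c1` is not yet measured. It differs from compound 3 in one place: 3-(trifluoromethyl)phenyl in place of (3-(trifluoromethyl)phenyl)amino on a carbonyl carbon. Among the measured compounds shown here, none of the measured steps touches the urea linkage itself; each one leaves the urea intact and varies only its aryl substituents, so there is no step in the set that bears on this change. For the measured compounds named here, with no precedent, the working expectation is a step of a number 4 percentage points higher from compound 3 to compound 4 (within the scatter) from compound 3 to compound 4, that is, no shift beyond the scatter. Compound 4 is therefore estimated at 75% in this assay, with a range of 55% to 95% that allows for a wider change in either direction.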

Compound 4, a percentage reported as activity, at one concentration (the size of the read-out at that concentration, not a potency): 97%
Compound 4: the middle estimate sits 22 percentage points below what was measured, outside the stated range (above it).
By their numbers in this assay, from the lowest: compounds 1 and 3 (each within the scatter of the next); then compound 2; then compound 4.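

Working notes on the linkage: in this assay the urea linkage is not a neutral spacer, as the earlier aryl changes could not show, since a number 26 percentage points higher from compound 3 to compound 4 (beyond the scatter) when the (3-(trifluoromethyl)phenyl)amino on the carbonyl carbon gives way to 3-(trifluoromethyl)phenyl, removing the amino nitrogen and its hydrogen-bond donor while the aromatic ring and its trifluoromethyl stay. The two other steps to the amide change the aryl substitution as well, and they also end beyond the scatter: a number 14 percentage points higher from compound 2 to compound 4 (beyond the scatter) and a number 35 percentage points higher from compound 1 to compound 4 (beyond the scatter), which makes compound 4 the weakest of the four at the one concentration tested. Nothing available explains why the amide loses the effect in this assay.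

From the compounds shown here alone, a single amide carries this conclusion, so it remains open whether the 4-chloro-3-(trifluoromethyl)phenyl group, which gives the lowest number among the ureas, would recover any effect on the same amide linkage. Going by these compounds, it is also open whether a thiourea, a sulfonamide or a reversed amide at this place would track the urea or the amide.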